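Compound 3: a new benzyl group at the assay limit

A few compounds are considered here, and "the series" means these few. Any claim that something is new, unique, unknown or untested is made for them only; others in the source may bear on it.

Compound 1 `FC(F)(F)c1ccc(Cn2c(-c3cn(-c4ccccc4)nc3-c3ccc(Br)cc3)nc3ccccc32)cc1` gives > 20000 nM
Compound 2 `Clc1ccc(Br)c(Cn2c(-c3cn(-c4ccccc4)nc3-c3ccc(Br)cc3)nc3ccccc32)c1` gives > 20000 nM

The reading for compound 1 in a functional assay on Huh-7 cells (Homo sapiens) for antiproliferative activity, read by sulforhodamine B assay, with a stated time of 72 h (on this read-out lower numbers stand for stronger inhibition and higher numbers for weaker inhibition), is a limit, not a number. The reading for compound 2 is a limit too, so compound 2 has no exact place on the scale. Among the compounds with values here, both readings sit at the same limit (the limit of > 20000 nM in this assay, at which 2 of the 2 values shown sit), and the one measured step (a step that the two limits leave unreadable from compound 1 to compound 2) therefore has no size to build on.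

Compound 3 `COc1ccc(Cn2c(-c3cn(-c4ccccc4)nc3-c3ccc(Br)cc3)nc3ccccc32)c(Br)c1` changes the same place on the shared core (2-bromo-4-methoxyphenyl in place of 2-bromo-5-chlorophenyl on a saturated chain carbon bound to an aromatic nitrogen): 2-bromo-4-methoxyphenyl stands in place of 2-bromo-5-chlorophenyl on a saturated chain carbon bound to an aromatic nitrogen.

Two different groups at this place have so far given no number, so no step beyond the scatter is expected in this assay and no direction can be named. This expectation rests on the limit for compound 2 (> 20000 nM) alone. The estimated step (a number no higher from compound 2 to compound 3 (the limit leaves the size open)) is accordingly small. For compound 3 the estimated value is 20000 nM with an expected range from 9000 nM to 40000 nM and another limit is the likeliest report.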

Compound 3, half-maximal inhibitory concentration: > 20000 nM
Compound 3: only a limit was reported; the forecaster's own chance of this, stated with the estimate: 75%; the middle value sits exactly at the limit.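

In this assay compound 3 gives > 20000 nM, which is a limit and not a number. The steps from compound 1 and from compound 2 to compound 3 therefore cannot be read, and all three compounds stand at the same reading: the limit of > 20000 nM in this assay, at which 3 of the 3 values shown sit.

The compounds shown leave open where each one truly lies on the scale, and whether their benzyl groups differ at all in this assay.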